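This account rests on a few compounds, and the source may have more. Where it says the series, first, only, none or still open, it means among the compounds named here.

Going by the values given here, in an ADME assay on HEK-293T cells (Homo sapiens) for cytotoxicity, read by luminescence, with a stated time of 24 h (a higher number here means that more compound is tolerated, a lower number that less compound is tolerated), compound 2 `CCCNC(=O)C1CCN(C(=O)c2cc3sccc3n2Cc2ccc(OC)cc2)CC1` gives 18800 nM, the only actual number so far. Compound 1 `COc1ccc(Cn2c(C(=O)N3CCC(C(=O)NCc4ccccc4)CC3)cc3sccc32)cc1` reads > 100000 nM, which is a limit. Compound 3 `CCCNC(=O)C1CCN(C(=O)c2cc3sc(C#N)cc3n2Cc2ccc(OC)cc2)CC1` reads > 100000 nM, again a limit. Compound 4 `CCCNC(=O)C1CCN(C(=O)c2c(Br)c3sccc3n2Cc2ccc(OC)cc2)CC1` differs from compound 2 by one change: bromo in place of hydrogen on an aromatic carbon. The nearest guide is an at least 5.3-fold higher number from compound 2 to compound 3 (0.72 log units; beyond the scatter), where cyano replaces hydrogen on an aromatic carbon. The other measured step, an at least 5.3-fold lower number from compound 1 to compound 2 (0.72 log units; beyond the scatter), concerns the amide side chain and bears little on this change. Both sizes rest on a limit at one end, and bromo is not cyano, so only a lean towards a higher number is expected, with no step beyond the scatter assured. The expected change is a 1.5-fold higher number from compound 2 to compound 4 (0.17 log units; within the scatter). For compound 4 the estimate is 28000 nM, with an expected range of 10000 nM to 100000 nM.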

Compound 4, half-maximal cytotoxic concentration: 31600 nM
Estimate against measurement, compound 4: 1.1-fold (0.05 log units) below, within the range that was stated.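

In this assay, bromo in place of hydrogen on the aromatic carbon next to the ring atom that bears a large group gives a 1.7-fold higher number from compound 2 to compound 4 (0.23 log units; within the scatter), so this position takes a bromine without a step beyond the scatter. Compound 2 and compound 4 both give actual numbers, which makes this the one step shown with no limit at either end: the limit of > 100000 nM in this assay, at which 2 of the 4 values shown sit.

Going by these compounds, whether an amine or a carboxylic acid on this carbon would also stay within the scatter of compound 2 remains open. The full size of the step to compound 3 is open too, as its value is a limit.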